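The source may hold more compounds than are shown below. What is called first, only, known or untested is meant among the compounds shown, and "the series" means these compounds.

Within the data shown here, in a physicochemical assay for solubility, with a stated time of 4 h, at pH 7.4 (a higher number here means a more soluble compound, a lower number a less soluble compound), compound 1 `Cc1cc(/C=C/C#N)cc(C)c1Oc1cc(Nc2ccc(C#N)cc2)c(N)cc1[N+](=O)[O-]` gives 0.29 ug/mL and compound 2 `Cc1cc(/C=C/C#N)cc(C)c1Oc1cc(Nc2ccc(C#N)cc2)c(N)cc1CO` gives 3.23 ug/mL, the higher of the two numbers so far. Compound 3 `CNC(=O)c1cc(N)c(Nc2ccc(C#N)cc2)cc1Oc1c(C)cc(/C=C/C#N)cc1C` differs from compound 2 by methylcarbamoyl in place of hydroxymethyl on an aromatic carbon. Among the measured compounds shown here, the only measured step that bears on this is an 11-fold higher number from compound 1 to compound 2 (1.05 log units; beyond the scatter), a large step beyond the scatter, and it brought in the hydroxymethyl that now leaves. For the measured compounds named here, no measured step introduces methylcarbamoyl, so only a slight fall in this assay, within the scatter, is expected. The expected step is a 1.6-fold lower number from compound 2 to compound 3 (0.21 log units; within the scatter). For compound 3 the estimate is 2 ug/mL, with an expected range of 0.6 ug/mL to 7 ug/mL.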

Compound 3, solubility: 1.32 ug/mL
The estimate for compound 3 lay 1.5-fold (0.18 log units) above the measured number; the measured number falls inside the stated range.
By their numbers in this assay, from the lowest: compound 1; then compound 3; then compound 2.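

In this assay, methylcarbamoyl in place of hydroxymethyl gives a 2.4-fold lower number from compound 2 to compound 3 (0.39 log units; beyond the scatter) on the aromatic carbon para to a (4-cyanophenyl)amino group, so this position still responds to change once nitro is gone. Methylcarbamoyl in place of nitro gives a 4.6-fold higher number from compound 1 to compound 3 (0.66 log units; beyond the scatter) at the same carbon, and the order from the lowest number is nitro, methylcarbamoyl, hydroxymethyl. Nothing available accounts for this order.

From the compounds shown here alone, whether an aminomethyl group or a carboxylic acid at this carbon would fall within this order remains open. Also open, going by these compounds, is whether the order holds when other parts of the shared core change.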